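Trading a dihydroxylated chain for an alkenyl chain

The source may report more compounds than this note shows. Statements on the series, on what has been measured and on what is new or still open speak of the compounds shown alone.

In a physicochemical assay for lipophilicity, read by HPLC, measured as octanol-water partition (a higher number here means a more lipophilic compound, a lower number a more polar compound), compound 1 `CC(C)(O)C(O)Cc1c(O)cc(/C=C/c2ccc(O)cc2)cc1O` gives 1.59, while compound 2 `CC(C)(O)C(O)Cc1c(O)cc(/C=C/c2ccccc2)cc1O` gives 2.59, the higher of the two numbers. The next structure, compound 3 `CC(C)/C=C/c1c(O)cc(/C=C/c2ccccc2)cc1O`, differs from compound 2 in one place: 3-methylbut-1-en-1-yl in place of 2,3-dihydroxy-3-methylbutyl on an aromatic carbon. Among the compounds with values here, only one measured step bears on this change. Hydrogen in place of hydroxy on an aromatic carbon gave a number 1.00 log units higher from compound 1 to compound 2 (beyond the scatter). That step removed a hydroxy from an aromatic carbon, whereas here the hydroxy groups leave with a chain, so it is a better guide to direction than to size. A rise beyond the scatter, somewhat larger than that measured step, is therefore expected in this assay. The expected change is a number 1.71 log units higher from compound 2 to compound 3 (beyond the scatter). For compound 3 the estimated value is 4.3, with an expected range from 3.6 to 5.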

Compound 3, partition coefficient: 3.71
Compound 3: middle estimate off by 0.59 log units, on the high side, and the stated range covers the measured number.
By their numbers in this assay, from the lowest: compound 1; then compound 2; then compound 3.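

Exchanging 2,3-dihydroxy-3-methylbutyl for 3-methylbut-1-en-1-yl, on the aromatic carbon ortho to two hydroxy groups, gives a number 1.12 log units higher from compound 2 to compound 3 (beyond the scatter) in this assay. Within the data shown here, the earlier compounds held this chain fixed, so this is the first reading at this position, and its direction matches a number 1.00 log units higher from compound 1 to compound 2 (beyond the scatter) from the change elsewhere on the core. The exchange alters several features at once: the entering chain has 0 hydrogen-bond donors against 2 in the leaving chain, along with fewer heavy atoms and a double bond, so the step cannot be assigned to any one of them.

Still open, from the compounds shown here alone, is how the number would respond at this position to a saturated 3-methylbutyl chain, a longer chain, an amine or a carboxylic acid. No measurement at hand accounts for the size of this step.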